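Para-substituent removal on the phenyl ring of compound 3

The source may hold more compounds than are shown below. What is called first, only, known or untested is meant among the compounds shown, and "the series" means these compounds.

Compound 3 `Fc1ccc(-c2nn3c(NC4CCCC4)ccnc3c2-c2ccnc(NC3CCCC3)c2)cc1` gives 16000 nM in an ADME assay on Vero cells (Chlorocebus sabaeus) for cytotoxicity; on this read-out lower numbers stand for higher toxicity in this test and higher numbers for lower toxicity in this test; compound 2 `COc1ccc(-c2nn3c(NC4CCCC4)ccnc3c2-c2ccnc(NC3CCCC3)c2)cc1` gives 10000 nM in this assay, and the two lie within the scatter of one another. Compound 1 `Fc1ccc(-c2nn3c(N4CCCC4)nccc3c2-c2ccnc(NC3CCCC3)n2)cc1` reaches only a limit in this assay, > 40000 nM, so it is not a number. Going by the values given here, the one measured step, a 1.6-fold higher number from compound 2 to compound 3 (0.20 log units; within the scatter), was itself within the scatter. Compound 4 `c1ccc(-c2nn3c(NC4CCCC4)ccnc3c2-c2ccnc(NC3CCCC3)c2)cc1` differs from compound 3 by hydrogen in place of fluoro on an aromatic carbon. Among the compounds with values here, no measured pair swaps fluoro for hydrogen, but the single change at this same aromatic carbon moved the read-out in this assay only within the scatter, so no step beyond the scatter is expected here: no change at the digits printed from compound 3 to compound 4 (within the scatter). Compound 4 is therefore estimated at 16000 nM in this assay, with a range from 8000 nM to 32000 nM.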

Compound 4, half-maximal cytotoxic concentration: 14000 nM
The estimate for compound 4 lay 1.1-fold (0.06 log units) above the measured number; the range from low to high includes it.
By their numbers in this assay, from the lowest: compounds 2, 4 and 3 (each within the scatter of the next). At a limit, above all of these: compound 1.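

In this assay, hydrogen in place of fluoro on this aromatic carbon leaves the read-out unchanged within the scatter: a 1.1-fold lower number from compound 3 to compound 4 (0.06 log units; within the scatter), and a 1.4-fold higher number from compound 2 to compound 4 (0.15 log units; within the scatter). Hydrogen, fluoro and methoxy at this position now all lie within the scatter of one another, whereas the earlier compounds compared only two groups here. Compounds 2, 3 and 4 all give numbers, so these steps are read clear of the one limit in the set: the limit of > 40000 nM in this assay, at which 1 of the 4 values shown sits.

On these data alone, whether an amine, a carboxylic acid or a longer chain on this aromatic carbon would also stay within the scatter remains open.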